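Methylating the ring amine of compound 2

The compounds below may be only part of what the source reports. "The series", "measured", "known", "first", "only" and "open" are said of these compounds alone.

Going by the values given here, compound 2 `COc1ccccc1-c1cc(C2CCNC2)ccc1Cl` gives 590 nM in an assay on isolated protein for binding affinity to 5-hydroxytryptamine receptor 3A (Homo sapiens) (a lower number here means a stronger inhibitor, a higher number a weaker inhibitor), the only numeric value in this pair. Compound 1 `CCCN(CCC)Cc1ccc(Cl)c(-c2ccccc2OC)c1` returns a limit of this assay, > 10000 nM, and no number. Compound 3 `COc1ccccc1-c1cc(C2CCN(C)C2)ccc1Cl` differs from compound 2 by methyl in place of hydrogen on an amine nitrogen in a ring. Among the compounds with values here, no measured pair shows this change, so its size is open. The expected step in this assay is a 1.3-fold lower number from compound 2 to compound 3 (0.12 log units; within the scatter), small and not clearly beyond the scatter in either direction. Compound 3 is estimated at 450 nM, within a range of 120 nM to 2000 nM.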

Compound 3, inhibition constant: 420 nM
Beside the measured number, compound 3's estimate is 1.1-fold (0.03 log units) above it; measured number inside the range.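

Going by these compounds alone, on the amine nitrogen of the five-membered non-aromatic ring, the first readable pair in this assay gives a 1.4-fold lower number from compound 2 to compound 3 (0.15 log units; within the scatter) for methyl in place of hydrogen. This nitrogen therefore carries either hydrogen or methyl with no change beyond the scatter, something the limit of compound 1 could not show. Nothing measured here bears on a cause for this step.

From the compounds shown here alone, whether a longer chain such as propyl, or a benzyl group, on this nitrogen keeps the number in this range stays open. So does the effect of an amide at this nitrogen.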